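A Methyl Added to Compound 2

The source may report more compounds than this note shows. Statements on the series, on what has been measured and on what is new or still open speak of the compounds shown alone.

Of the compounds shown here, two have been tested in an ADME assay on microsomes from liver (Mus musculus) for metabolic stability; a higher number here means faster removal of the compound, a lower number slower removal. Compound 1 `CN1C(=O)C2=C(C1=O)N(CC(=O)Nc1ccc(-c3ccccc3)cn1)CCC2` gives 67 mL.min-1.g-1 in this assay. Compound 2 `CN1C(=O)C2=C(C1=O)N(CC(=O)Nc1ccc(-c3cccnc3)nn1)CCC2` gives 12 mL.min-1.g-1 in this assay, the lower of the two numbers and beyond the scatter from compound 1. Compound 3 `Cc1ccc(-c2ccc(NC(=O)CN3CCCC4=C3C(=O)N(C)C4=O)nn2)cn1` is not yet measured; it differs from compound 2 by methyl in place of hydrogen on an aromatic carbon. Among the measured compounds shown here, no measured pair shows this change. A small step in this assay is expected, if any, most likely toward a higher number a 1.5-fold higher number from compound 2 to compound 3 (0.18 log units; within the scatter). Compound 3 is therefore estimated at 18 mL.min-1.g-1, with a range from 7 mL.min-1.g-1 to 45 mL.min-1.g-1.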

Compound 3, intrinsic clearance in microsomes in the liver assay: 8 mL.min-1.g-1
Compound 3: the middle estimate sits 2.3-fold (0.35 log units) above what was measured, within the range that was stated.
By their numbers in the liver assay, from the lowest: compounds 3 and 2 (each within the scatter of the next); then compound 1.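

On this aromatic carbon next to the ring nitrogen, methyl in place of hydrogen gives in the liver assay only a 1.5-fold lower number from compound 2 to compound 3 (0.18 log units; within the scatter), while in a physicochemical assay for solubility, measured as thermodynamic solubility, at pH 4 (a higher number here means a more soluble compound, a lower number a less soluble compound), the same change gives an at least 13-fold higher number from compound 2 to compound 3 (1.14 log units; beyond the scatter). In the physicochemical assay compound 2 gives 13.9 ug/mL. In the physicochemical assay compound 3 gives > 194 ug/mL, which is a limit of the assay and not a number.

The compounds shown leave open whether an ethyl group, a methoxy group or an amine on this same carbon would behave like methyl in either assay. One pair also cannot tell what methyl would do on another carbon of this ring.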